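The source may hold more compounds than are shown below. What is called first, only, known or untested is meant among the compounds shown, and "the series" means these compounds.

Measured so far in a functional assay on FM3A cells (Mus musculus) for inhibition, read by cell counting, with a stated time of 2 days; a higher number here means a weaker inhibitor, a lower number a stronger inhibitor:

compound 1, `C=C(Br)C(=O)Nc1cccc(-c2cn3nc(-c4ccc(F)cc4)sc3n2)c1`, gives 610 nM
compound 2, `C=C(Br)C(=O)Nc1cccc(-c2cn3nc(-c4ccc(OCC)cc4)sc3n2)c1`, gives 1100 nM
compound 3, `C=C(Br)C(=O)Nc1cccc(-c2cn3nc(Cc4ccc(Cl)cc4)sc3n2)c1`, gives 1100 nM

All three share the same core and differ only in the group on one aromatic carbon of the fused ring system. Compound 3 stands level with compound 2: there is no change at the digits printed from compound 2 to compound 3 (within the scatter). Against compound 1 there is a 1.8-fold higher number from compound 1 to compound 3 (0.26 log units; within the scatter), and likewise a 1.8-fold higher number from compound 1 to compound 2 (0.26 log units; within the scatter), so none of the three exchanges at this position moved the number beyond the scatter of this assay.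

Compound 4, `C=C(Br)C(=O)Nc1cccc(-c2cn3nc(-c4cccs4)sc3n2)c1`, has not yet been measured. It differs from compound 3 by thiophen-2-yl in place of 4-chlorobenzyl on an aromatic carbon. Every step measured so far swaps the group at the same aromatic carbon. Each of those steps was within the scatter. Nothing in the data singles out the thiophen-2-yl group, so the same is expected here: a step in this assay of a 1.2-fold lower number from compound 3 to compound 4 (0.09 log units; within the scatter), with no direction beyond the scatter. Compound 4 is therefore expected to come in at about 900 nM, with a range from 350 nM to 2500 nM.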

Compound 4, half-maximal inhibitory concentration: 370 nM
Compound 4: the middle estimate sits 2.4-fold (0.39 log units) above what was measured; measured number inside the range.
By their numbers in this assay, from the lowest: compounds 4, 1, 2 and 3 (each within the scatter of the next, the first and the last beyond it).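

In this assay, this aromatic carbon now shows a response beyond the scatter: thiophen-2-yl gives a 3.0-fold lower number from compound 3 to compound 4 (0.47 log units; beyond the scatter) and a 3.0-fold lower number from compound 2 to compound 4 (0.47 log units; beyond the scatter), whereas no exchange among the first three groups moved the number that far. The exchange of 4-fluorophenyl for thiophen-2-yl gives a 1.6-fold lower number from compound 1 to compound 4 (0.22 log units; within the scatter), so compound 4 separates from the 4-chlorobenzyl and 4-ethoxyphenyl compounds but not from the 4-fluorophenyl compound, and thiophen-2-yl cannot be ranked above 4-fluorophenyl here. No measurement bearing on why the number shifts with this exchange is available.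

The compounds shown leave open whether the ring sulfur or the five-membered ring accounts for the step, a question that furan-2-yl, thiophen-3-yl and unsubstituted phenyl at this carbon could help to separate. They also leave open how this position would respond to a group without an aromatic ring, such as an amine, a carboxylic acid or a longer alkyl chain.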